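The source may report more compounds than this note shows. Statements on the series, on what has been measured and on what is new or still open speak of the compounds shown alone.

Compound 1 `Oc1cccc(-c2cc(-c3ccccc3)cc(-c3ccsc3)n2)c1` and compound 2 `Oc1cccc(-c2cc(-c3ccccc3)cc(-c3ccco3)n2)c1` share one core; compound 3 `Oc1cccc(-c2cc(-c3ccccc3)nc(-c3ccsc3)c2)c1` and compound 4 `Oc1cccc(-c2cc(-c3ccccc3)nc(-c3ccco3)c2)c1` share another. Compound 1 and compound 3 are built from the same atoms joined differently, and the difference between the two cores is not broken down here.

In a functional assay on DU-145 cells (Homo sapiens) for cytotoxicity, read by ELISA, with a stated time of 2 days (on this read-out higher numbers stand for weaker inhibition and lower numbers for stronger inhibition), compound 1 gives 11700 nM, and compound 2 gives 14400 nM. The change between them is furan-2-yl in place of thiophen-3-yl on an aromatic carbon. That step, a 1.2-fold higher number from compound 1 to compound 2 (0.09 log units; within the scatter), stays within the scatter of repeated measurements.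

Compound 3 gives 11700 nM in this assay, a number level with compound 1 at the digits printed. Compound 4 differs from compound 3 by furan-2-yl in place of thiophen-3-yl on an aromatic carbon, which is the same change as that from compound 1 to compound 2, at a place described in the same words.

Because the measured pair showed a 1.2-fold higher number from compound 1 to compound 2 (0.09 log units; within the scatter), the step of a 1.2-fold higher number from compound 3 to compound 4 (0.08 log units; within the scatter) is the expected size, with no reason to expect more. Compound 4 is therefore estimated to give 14000 nM in this assay, between 7000 nM and 28000 nM.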

Compound 4, half-maximal inhibitory concentration: 34900 nM
Compound 4: middle estimate off by 2.5-fold (0.40 log units), on the low side, outside the stated range (above it).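

Placing furan-2-yl where thiophen-3-yl stood on the core of compound 3 gives a 3.0-fold higher number from compound 3 to compound 4 (0.47 log units; beyond the scatter) in this assay, a step beyond the usual scatter, whereas the same change on the core of compound 1 stayed within it. Set side by side, the two steps are no further apart than repeated measurements could make them: the same change on two cores in this assay, a 1.2-fold higher number (0.09 log units; within the scatter) from compound 1 to compound 2 and a 3.0-fold higher number (0.47 log units; beyond the scatter) from compound 3 to compound 4, 2.4-fold (0.38 log units) apart, within the scatter of two such steps

So the data give no firm sign that the core alters the effect of this change, yet with only one pair on each core they cannot show that the two cores truly respond alike.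

The compounds shown leave open how either core would respond to a different kind of group at this place, such as an amine or a carboxylic acid, rather than another five-membered aromatic ring. On these data alone, it also remains open whether the step seen in this assay would hold in any other assay.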